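Thiophene isomer swap on a dihydropyrimidine series

The source may hold more compounds than are shown below. What is called first, only, known or untested is meant among the compounds shown, and "the series" means these compounds.

Measured so far:
- compound 1 `CC1=C(C(=O)OC(C)(C)C)C(c2cccs2)NC(=O)N1`: 26%
- compound 2 `CC1=C(C(=O)OC(C)(C)C)C(c2ccsc2)NC(=O)N1`: 15%
- compound 3 `COC(=O)C1=C(C)NC(=S)NC1c1cccs1`: 1%

All three were tested in an assay on membranes from CHO cells for displacement of a labelled ligand from adenosine receptor A1 (Homo sapiens), read by scintillation counting, with a stated time of 60 min, tested at 1 uM; on this read-out lower numbers stand for less inhibition and higher numbers for more inhibition at the one concentration tested (going by the name of the read-out). Compound 1 gives 26% and compound 2 gives 15%; the step between them is thiophen-3-yl in place of thiophen-2-yl on a saturated ring carbon, and it made a number 11 percentage points lower from compound 1 to compound 2 (beyond the scatter). Compound 3 gives 1% in this assay, the lowest of the three numbers; the difference between the core of compound 3 and the core of compound 1 is not broken down here.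

Compound 4 `COC(=O)C1=C(C)NC(=S)NC1c1ccsc1` is not yet measured. It stands to compound 3 as compound 2 stands to compound 1: thiophen-3-yl in place of thiophen-2-yl on a saturated ring carbon. The place differs in its surroundings, since in compound 3 the saturated ring carbon is next to the ring atom that bears a methoxycarbonyl group, whereas in compound 1 it is next to the ring atom that bears a group of 7 heavy atoms; so this is the same kind of change, not the same one.

Because compound 3 already gives 1%, little room remains for a lowering in this assay, and the step is expected to be smaller than a number 11 percentage points lower from compound 1 to compound 2 (beyond the scatter): compound 4 is expected to move by a number 1 percentage points higher from compound 3 to compound 4 (within the scatter). Compound 4 is thus estimated at 2% in this assay, between -8% and 12%.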

Compound 4, a percentage reported as inhibition, at one concentration (the size of the read-out at that concentration, not a potency): 3%
Compound 4: the middle estimate sits 1 percentage points below what was measured, and the stated range covers the measured number.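

In this assay, thiophen-3-yl in place of thiophen-2-yl on a saturated ring carbon gives a number 2 percentage points higher from compound 3 to compound 4 (within the scatter) on the second core, and the two steps cannot be told apart: the same change on two cores in this assay, a number 11 percentage points lower (beyond the scatter) from compound 1 to compound 2 and a number 2 percentage points higher (within the scatter) from compound 3 to compound 4, 13 percentage points apart, within the scatter of two such steps. The step seen on the core of compound 1 therefore neither clearly carries over to the core of compound 3 nor clearly fails to, since compound 3 at 1% and compound 4 at 3% both sit close to the bottom of the read-out, where a lowering would have little room to show. With one pair on each core and one concentration, these numbers support no rule on the thiophene isomers for the series.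

On these data alone, the cores of compound 1 and compound 3 differ in more than one place, so the contribution of each difference stays open. Also open, as far as these compounds go, is how the series responds to a carboxylic acid at the ester position or to a longer chain in place of the methyl group.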